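A ring enters compound 2

The source may hold more compounds than are shown below. What is called first, only, known or untested is meant among the compounds shown, and "the series" means these compounds.

Values from a functional assay on HepG2 cells (Homo sapiens) for inhibition, read by MTT assay, with a stated time of 48 h (a higher number here means a weaker inhibitor, a lower number a stronger inhibitor), follow
compound 1 `CCOC(=O)C1=C(N/N=C(\c2ccc([N+](=O)[O-])cc2)N2CCN(c3ccc(F)cc3)CC2)Nc2[nH]nc(C)c2C1c1ccc(N(C)C)cc1` gives 90200 nM
compound 2 `CCOC(=O)C1=C(N/N=C(\C#N)C(N)=O)Nc2[nH]nc(C)c2C1c1ccc(N(C)C)cc1` gives 48400 nM
compound 3 `CCOC(=O)C1=C(N/C=N/c2ncc(-c3ccccc3)s2)Nc2[nH]nc(C)c2C1c1ccc(N(C)C)cc1` gives 9790 nM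

Compound 2 stands within the scatter of compound 1, and its number is clearly higher than that of compound 3 (9790 nM), the one clearly stronger inhibitor of the three. Compound 4 `CCOC(=O)C1=C(N/C=N/c2ccccn2)Nc2[nH]nc(C)c2C1c1ccc(N(C)C)cc1` differs from compound 2 in one place, on an amine nitrogen (a group of 8 heavy atoms (6 carbon, 2 nitrogen; one six-membered aromatic ring with 1 hetero atom) in place of a group of 7 heavy atoms (3 carbon, 3 nitrogen, 1 oxygen; no ring), on an amine nitrogen). A six-membered aromatic ring with 1 hetero atom replaces a group with no ring. Within the data shown here, no step between measured compounds shows such a change, so the expectation is loose: a moderate step to a lower number is expected in this assay and lies inside the measured span. The expected step is a 2.4-fold lower number from compound 2 to compound 4 (0.38 log units; beyond the scatter) and remains uncertain. Compound 4 is estimated at 20000 nM (expected range 6000 nM to 60000 nM).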

Compound 4, half-maximal inhibitory concentration: 26200 nM
Estimate against measurement, compound 4: 1.3-fold (0.12 log units) below; the measured number falls inside the stated range.
By their numbers in this assay, from the lowest: compound 3; then compounds 4, 2 and 1 (each within the scatter of the next, the first and the last beyond it).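

In this assay, a six-membered aromatic ring in place of the open-chain group on the amine nitrogen gives a 1.8-fold lower number from compound 2 to compound 4 (0.27 log units; within the scatter), so the mere presence of a ring does not separate these two compounds. Pyridin-2-yl in place of 5-phenyl-1,3-thiazol-2-yl gives a 2.7-fold higher number from compound 3 to compound 4 (0.43 log units; beyond the scatter), so which ring is present does count here. Nothing measured here explains either step. The compounds shown leave open whether an unsubstituted 1,3-thiazol-2-yl group would stay with compound 3 or with compound 4, and so whether the difference lies in the phenyl or in the thiazole.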